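The compounds below may be only part of what the source reports. "The series", "measured", "known", "first", "only" and "open" are said of these compounds alone.

Compound 3 `Cc1cc(NCc2ccccn2)n2ncc(-c3cc(F)c(F)c(F)c3)c2n1` is the point of departure. In a physicochemical assay for solubility, read by HPLC, using the shake flask method, measured as kinetic solubility, with a stated time of 2 h, at pH 7.4 (a lower number here means a less soluble compound, a higher number a more soluble compound), compound 3 gives < 5000 nM, which is a limit of the assay and not a number. Compound 1 `Cc1cc(NCc2ccccn2)n2ncc(-c3ccc(F)cc3)c2n1` also sits at a limit in this assay, where compound 1 gives < 5000 nM. Compound 2 `Cc1cc(NCc2ccccn2)n2ncc(Br)c2n1` carries bromo instead of an aryl group and gives 89300 nM in this assay. The measured steps run an at least 17-fold higher number from compound 1 to compound 2 (1.25 log units; beyond the scatter) and an at least 17-fold lower number from compound 2 to compound 3 (1.25 log units; beyond the scatter), while the step that the two limits leave unreadable from compound 1 to compound 3 cannot be read, since (the limit of < 5000 nM in this assay, at which 2 of the 3 values shown sit). Compound 4 `Cc1cc(NCc2ccccn2)n2ncc(-c3ccn(C)n3)c2n1` differs from compound 3 in one place: 1-methyl-1H-pyrazol-3-yl in place of 3,4,5-trifluorophenyl on an aromatic carbon. For the measured compounds named here, none of the measured steps exchanges one aromatic ring for another; the two readable steps show that giving up a fluorophenyl ring in favour of bromo raised the number well beyond the scatter, and that bringing such a ring back lowered it by as much. Compound 4 keeps a ring, but a five-membered one with two hetero atoms, for which no step is shown. Compound 4 is therefore expected to move upward from the limit, by an estimated at least 6.0-fold higher number from compound 3 to compound 4 (0.77 log units; beyond the scatter), though a value at the limit remains possible. The estimate for compound 4 in this assay is 30000 nM, with a range from 5000 nM to 150000 nM.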

Compound 4, solubility: 188000 nM
Estimate against measurement, compound 4: 6.3-fold (0.80 log units) below; the measured number lies above the stated range.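

In this assay, an aromatic ring on this carbon does not by itself hold the number down: 1-methyl-1H-pyrazol-3-yl gives an at least 37-fold higher number from compound 3 to compound 4 (1.57 log units; beyond the scatter) in place of 3,4,5-trifluorophenyl, and an at least 37-fold higher number from compound 1 to compound 4 (1.57 log units; beyond the scatter) in place of 4-fluorophenyl. Until now, only the loss of such a ring had raised the number, yet this ring also exceeds bromo, with a 2.1-fold higher number from compound 2 to compound 4 (0.32 log units; beyond the scatter), so that compound 4 stands highest of the four and goes against the link between a ring and a low reading that compounds 1, 2 and 3 suggested. The two larger steps give only a lower bound on their size, and the step between the two fluorinated compounds still cannot be read: the limit of < 5000 nM in this assay, at which 2 of the 4 values shown sit.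

The compounds shown leave open which feature of the entering ring goes with the higher number: its two nitrogens, its methyl group or its five-membered size. They also leave open how a phenyl ring carrying a morpholine or a carboxylic acid, or a pyridine ring, would read on this carbon in this assay.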